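The source may report more compounds than this note shows. Statements on the series, on what has been measured and on what is new or still open speak of the compounds shown alone.

Working notes on the series. Compound 1 `CS(=O)(=O)c1ccc(-c2cnc3[nH]cc(-c4nnc(-c5ccccn5)o4)c(=O)c3c2)cc1` has been tested in a functional assay on HCT-116 cells (Homo sapiens) for inhibition, read by MTT assay, with a stated time of 24 h, tested at 10 uM (on this read-out lower numbers stand for less inhibition of growth and higher numbers for more inhibition of growth at the one concentration tested), where compound 1 gives 16.2%. For the measured compounds named here, the only other measured member, compound 2 `O=c1c(-c2nnc(-c3ccc(Cl)cc3)o2)c[nH]c2ncc(-c3cccnc3)cc12`, gives 11.8% in this assay. The two numbers fall within the usual scatter of repeated measurements of one another, so the two measured compounds cannot be told apart on this read-out; both show modest inhibition at the single concentration tested. Going by the values given here, no step between measured compounds that differ in one place is available, so there is no measured precedent for any single structural change in this assay.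

Compound 3 `Cc1cccc(-c2nnc(-c3c[nH]c4ncc(-c5ccc(S(C)(=O)=O)cc5)cc4c3=O)o2)c1` has not yet been measured. Compared with compound 1 the change is 3-methylphenyl in place of pyridin-2-yl on an aromatic carbon. Among the compounds with values here, with no measured single-change step in the set, and with both measured compounds sitting in the same modest band, the expected step is a number 1.2 percentage points lower from compound 1 to compound 3 (within the scatter), none beyond the scatter. Compound 3 is accordingly estimated at 15% in this assay, with a range from 3% to 30%.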

Compound 3, percent growth inhibition at one concentration: 25.2%
Beside the measured number, compound 3's estimate is 10.2 percentage points below it; low and high end bracket the measured number.
By their numbers in this assay, from the lowest: compounds 2, 1 and 3 (each within the scatter of the next, the first and the last beyond it).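

At this position, an aromatic carbon of the five-membered aromatic ring with 2 nitrogen and 1 oxygen, the series now has its first change in one place: 3-methylphenyl in place of pyridin-2-yl gives a number 9 percentage points higher from compound 1 to compound 3 (within the scatter) in this assay. The two compounds therefore cannot be told apart on this read-out, and this position carries a six-membered aromatic ring of carbon only, with its methyl, as well as one with a ring nitrogen, with no step beyond the scatter. Nothing measured on the properties of these two groups bears on this step, so it stands without an explanation.

What an amine, a carboxylic acid or a longer alkyl chain would do on this carbon in this assay stays open, so the compounds shown do not tell whether an aromatic ring is needed here at all. For the compounds shown here, also open is how the methyl and the exchange of ring nitrogen for carbon each contribute, since the two arrive together in this one step, and whether the same change reads alike on a core with a different group in place of the one shared by compound 1 and compound 3.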